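Thiophen-3-yl in place of furan-3-yl on the shared core

This account rests on a few compounds, and the source may have more. Where it says the series, first, only, none or still open, it means among the compounds named here.

Measured compounds:
compound 1, `c1ccc(-c2c[nH]c(-c3ccco3)n2)cc1`: 37.7%
compound 2, `c1ccc(-c2c[nH]c(-c3ccoc3)n2)cc1`: 27.3%

In an in vitro assay on HEK293 cells for inhibition of sodium channel protein type 2 subunit alpha (Homo sapiens), read by patch clamp, tested at 100 uM (a higher number here means a stronger effect of the compound at the concentration tested, a lower number a weaker effect), compound 1 gives 37.7%, while compound 2 gives 27.3%. For the measured compounds named here, compound 2 thus holds the lower of the two numbers, and the only step between measured compounds, a number 10.4 percentage points lower from compound 1 to compound 2 (beyond the scatter), goes beyond the scatter but is modest in size.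

Compound 3, `c1ccc(-c2c[nH]c(-c3ccsc3)n2)cc1`, is not yet measured. It differs from compound 2 in one place: thiophen-3-yl in place of furan-3-yl on an aromatic carbon. Going by the values given here, no measured pair bears directly on this change: the step from compound 1 to compound 2 moved the point of attachment on the same ring, whereas here the ring keeps its point of attachment and sulfur stands where oxygen was. Among the compounds with values here, with no step of that kind on record, and the one measured step being modest, compound 3 is expected to stay close to compound 2, with a number 2.7 percentage points higher from compound 2 to compound 3 (within the scatter) not beyond the scatter. The estimate for compound 3 in this assay is 30%, with a range from 15% to 47%.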

Compound 3, a percentage reported as activity, at one concentration (the size of the read-out at that concentration, not a potency): 70.9%
Compound 3: middle estimate off by 40.9 percentage points, on the low side; the measured number lies above the stated range.
By their numbers in this assay, from the lowest: compound 2; then compound 1; then compound 3.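

In this assay, replacing the ring oxygen with sulfur at this position, on an aromatic carbon between two ring nitrogen atoms, gives a number 43.6 percentage points higher from compound 2 to compound 3 (beyond the scatter), a large step compared with the modest a number 10.4 percentage points lower from compound 1 to compound 2 (beyond the scatter) that came from moving the point of attachment on the furan. The thiophen-3-yl group also surpasses the furan-2-yl group, with a number 33.2 percentage points higher from compound 1 to compound 3 (beyond the scatter), which makes compound 3 the highest of the three, although the two groups exchanged in the latest step match in heavy atoms, hydrogen-bond donors and hydrogen-bond acceptors, so these counts do not separate them. Nothing available accounts for the size of this gain.

The compounds shown leave open whether the gain belongs to thiophen-3-yl alone or extends to thiophen-2-yl, and whether a plain phenyl ring or an aminomethyl group at the same place would keep it. Each number also gives the size of the effect at a single concentration, so the compounds can be compared only as having a stronger or weaker effect at that concentration.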